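Swapping the amide cap on a shared core

This account rests on a few compounds, and the source may have more. Where it says the series, first, only, none or still open, it means among the compounds named here.

Measured compounds:
- compound 1, `Cc1ccc(C(=O)Nc2nc(-c3ccccc3)nc3c2nnn3Cc2ccccc2)cc1`: 709 nM
- compound 2, `O=C(Nc1nc(-c2ccccc2)nc2c1nnn2Cc1ccccc1)C1CC1`: 7.5 nM

Both compounds share one core and differ only in the group attached to the carbonyl carbon of the amide. In an assay (strain Wistar) for displacement of a labelled ligand from adenosine receptor A1 (Rattus norvegicus), read by scintillation counting (on this read-out lower numbers stand for stronger inhibition and higher numbers for weaker inhibition), compound 2 gives the lower of the two numbers, and its nearest neighbour is compound 1, as the step of a 95-fold lower number from compound 1 to compound 2 (1.98 log units; beyond the scatter) shows: a large shift, well beyond the scatter.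

Compound 3, `O=C(Nc1nc(-c2ccccc2)nc2c1nnn2Cc1ccccc1)c1ccc([N+](=O)[O-])cc1`, is not yet measured. The change from compound 2 is 4-nitrophenyl in place of cyclopropyl on a carbonyl carbon. Going by the values given here, only one measured step bears on it, and it went the other way: leaving the cyclopropyl for a 4-methylphenyl gave the much higher number of compound 1. A return to a six-membered aromatic ring on the carbonyl carbon is therefore expected to raise the number again, toward the range of compound 1, though the nitro group in place of the methyl leaves the exact size uncertain. For compound 3 the expected step is a 53-fold higher number from compound 2 to compound 3 (1.73 log units; beyond the scatter), giving an estimated value of 400 nM with a range from 80 nM to 2000 nM.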

Compound 3, inhibition constant: 24 nM
Estimate against measurement, compound 3: 17-fold (1.22 log units) above; measured number below the stated range.
By their numbers in this assay, from the lowest: compound 2; then compound 3; then compound 1.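

Moving from the cyclopropyl to the 4-nitrophenyl gives a 3.2-fold higher number from compound 2 to compound 3 (0.51 log units; beyond the scatter) in this assay, a modest step, so an aromatic ring on the carbonyl carbon does not by itself bring the large rise seen with compound 1. What the ring carries matters just as much: nitro in place of methyl on an aromatic carbon gives a 30-fold lower number from compound 1 to compound 3 (1.47 log units; beyond the scatter), a large step within a single change. Compound 2 still has the lowest number of the three, but the distance from it to an aromatic group depends strongly on that ring substituent.

Nothing available explains why nitro and methyl differ so widely here. From the compounds shown here alone, it remains open how a plain phenyl, or a phenyl carrying an amine or a carboxylic acid, would fall relative to these compounds, and how a longer carbon chain would compare with the cyclopropyl.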